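The source may report more compounds than this note shows. Statements on the series, on what has been measured and on what is new or still open speak of the compounds shown alone.

Measured compounds:
Compound 1 `COc1ccc(/C=C/c2nc(-c3ccc4c(c3)CCC(=O)N4)cs2)cc1OC`: 2800 nM
Compound 2 `COc1cc(-c2nc(-c3ccc4c(c3)CCC(=O)N4)cs2)ccc1SC`: 400 nM
Compound 3 `CCOc1cc(-c2nc(-c3ccc4c(c3)CCC(=O)N4)cs2)ccc1OC`: 90 nM

All three compounds share one core and were tested in a functional assay for inhibition, with Homo sapiens as the target; a lower number here means a stronger inhibitor, a higher number a weaker inhibitor. Compound 2, at 400 nM, holds the second highest of the three numbers. Compound 3 reads lower at 90 nM, and compound 1 reads higher at 2800 nM. Both gaps from compound 2 lie beyond the scatter.

The next compound to be tested is compound 4 `COc1cc(-c2nc(-c3ccc4c(c3)CCC(=O)N4)cs2)ccc1[S+](C)[O-]`, which is derived from compound 2. The change is a group of 3 heavy atoms (1 carbon, 1 oxygen, 1 sulfur; no ring) in place of a group of 2 heavy atoms (1 carbon, 1 sulfur; no ring), on an aromatic carbon. The methylsulfanyl group leaves an aromatic carbon, ortho to a methoxy group and para to a large group, and the new group takes its place.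

Going by the values given here, no pair of measured compounds differs in one place only, so nothing here measures this change directly. Among the compounds with values here, the direction is therefore a judgement, and the only anchor is compound 2 at 400 nM. A moderate rise in the number is expected, meaning a weaker inhibitor, probably beyond the scatter, though a step within it cannot be ruled out. The estimated step is a 3.0-fold higher number from compound 2 to compound 4 (0.48 log units; beyond the scatter). The expected value for compound 4 is 1200 nM, with an estimated range from 300 nM to 5000 nM.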

Compound 4, half-maximal inhibitory concentration: 800 nM
Compound 4: middle estimate off by 1.5-fold (0.18 log units), on the high side; the range from low to high includes it.
By their numbers in this assay, from the lowest: compound 3; then compounds 2 and 4 (each within the scatter of the next); then compound 1.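

In this assay, going by these compounds alone, this pair gives the first comparison in the set that differs in one place only: swapping the methylsulfanyl group on this aromatic carbon, ortho to a methoxy group and para to a large group, for the group of 3 heavy atoms gives a 2.0-fold higher number from compound 2 to compound 4 (0.30 log units; within the scatter), so compound 2 and compound 4 cannot be told apart here. The earlier compounds shown here offered no reading of this position at all, whereas this pair shows that adding an oxygen to the sulfur, with no net charge and the same count of hydrogen-bond acceptors on both groups, leaves the result inside the scatter of repeated measurements. No measurement at hand accounts for this result.

The compounds shown leave open how a methylsulfonyl group, a chlorine atom or a dimethylamino group on the same aromatic carbon would read in this assay, so the reach of this single step across other groups remains unknown. They also leave open whether the same swap would give a similar step with an ethoxy group in place of the methoxy group on that ring.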